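Rat microsomal stability: benzyloxy for phenethyl at the ether

This account rests on a few compounds, and the source may have more. Where it says the series, first, only, none or still open, it means among the compounds named here.

Measured so far:
compound 1 `COc1nn2cc(-c3cc4ccc(OC)c(OC)c4o3)nc2s1` — 3%
compound 2 `COc1cc(OCc2cccc(CCc3ccccc3)c2)c2cc(-c3cn4nc(OC)sc4n3)oc2c1` — 68%

Both compounds were run in an ADME assay on microsomes from liver (Rattus norvegicus) for metabolic stability, with a stated time of 10 min; on this read-out lower numbers stand for a less stable compound and higher numbers for a more stable compound. Compound 1 gives 3% in this assay. Compound 2 gives 68% in this assay, the highest of the two numbers, and the gap to compound 1 is beyond the scatter. The two structures differ in more than one place, so nothing further is drawn from that pair.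

Compound 3 `COc1cc(OCc2cccc(OCc3ccccc3)c2)c2cc(-c3cn4nc(OC)sc4n3)oc2c1` is not yet measured. It differs from compound 2 in one place: benzyloxy in place of phenethyl on an aromatic carbon. The aryl ether and the rest of the molecule are unchanged; only the linker between the two phenyl rings is exchanged.

Going by the values given here, no measured pair of this kind exists, so the size of this step is open. With the bulk of the structure shared with compound 2, the expectation is for a step in this assay of a number 8 percentage points lower from compound 2 to compound 3 (within the scatter), no larger than the scatter or a little downward. Compound 3 is therefore estimated at 60% in this assay, within a range from 35% to 85%.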

Compound 3, percent of the compound remaining: 76%
Compound 3: the middle estimate sits 16 percentage points below what was measured; measured number inside the range.
By their numbers in this assay, from the lowest: compound 1; then compounds 2 and 3 (each within the scatter of the next).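

Notes on the ether side chain: in this assay, exchanging phenethyl for benzyloxy on this aromatic carbon gives a step of a number 8 percentage points higher from compound 2 to compound 3 (within the scatter), so this read-out does not separate the two linkers between the phenyl rings at this place, meta to a large group. Going by these compounds alone, this is the first single-place comparison, and it shows that this position accepts the exchange without a change beyond the scatter, even though benzyloxy carries 1 hydrogen-bond acceptor and phenethyl carries 0. No measurement at hand bears on what lies behind this result.

On these data alone, this reading rests on one pair, so it remains open whether it extends to other kinds of group at this place, such as an amine, a carboxylic acid or a longer chain between the two phenyl rings. Also open, as far as these compounds go, is whether the same exchange would read alike on a different aromatic carbon of this ring, or with a different group in place of the terminal phenyl.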